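This account rests on a few compounds, and the source may have more. Where it says the series, first, only, none or still open, it means among the compounds named here.

Of the compounds shown here, three that share one core have been measured. Compound 1 `CCOC(=O)c1cnc(NN2C(=O)C=C(C)C2=O)nc1-c1ccccc1` carries a phenyl group; in a functional assay on Jurkat cells (Homo sapiens) for inhibition (a lower number here means a stronger inhibitor, a higher number a weaker inhibitor), compound 1 gives 1200 nM. Compound 2 `CCOC(=O)c1cnc(NN2C(=O)C=C(C)C2=O)nc1-c1cccs1` carries thiophen-2-yl in that place, and in this assay compound 2 gives 140 nM. Compound 3 `CCOC(=O)c1cnc(NN2C(=O)C=C(C)C2=O)nc1-c1ccsc1` carries thiophen-3-yl; in this assay compound 3 gives 200 nM. Compound 3 thus sits second highest of the three numbers: its nearest neighbour is compound 2, a gap within the scatter, while compound 1 lies far above it, beyond the scatter.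

The change to compound 4 `CCOC(=O)c1cnc(NN2C(=O)C=C(C)C2=O)nc1-c1cc2ccccc2s1` is 1-benzothiophen-2-yl in place of thiophen-3-yl on an aromatic carbon. The measured steps show only that a thiophene gives a lower number than phenyl here (an 8.6-fold lower number from compound 1 to compound 2 (0.93 log units; beyond the scatter); a 6.0-fold lower number from compound 1 to compound 3 (0.78 log units; beyond the scatter)) and that the two thiophene attachments give much the same number (a 1.4-fold higher number from compound 2 to compound 3 (0.15 log units; within the scatter)). Within the data shown here, no step shows what fusing a benzene ring onto the thiophene does. Compound 4 keeps a five-membered aromatic ring with one sulfur. The step of a 1.1-fold lower number from compound 3 to compound 4 (0.05 log units; within the scatter) is therefore expected to stay within the scatter, with wide uncertainty. For compound 4 the estimate in this assay is 180 nM, with a range from 50 nM to 650 nM.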

Compound 4, half-maximal inhibitory concentration: 800 nM
Estimate against measurement, compound 4: 4.4-fold (0.65 log units) below; measured number outside the range, above it.
By their numbers in this assay, from the lowest: compounds 2 and 3 (each within the scatter of the next); then compounds 4 and 1 (each within the scatter of the next).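

In this assay, a benzene ring fused onto the thiophene is not a neutral change at this position, next to the ring nitrogen and ortho to the ethoxycarbonyl group: the result is a 4.0-fold higher number from compound 3 to compound 4 (0.60 log units; beyond the scatter), and against the thiophen-2-yl group, which has the same attachment, a 5.7-fold higher number from compound 2 to compound 4 (0.76 log units; beyond the scatter). The comparison with phenyl gives a 1.5-fold lower number from compound 1 to compound 4 (0.18 log units; within the scatter), so the low numbers of the two thiophenes do not carry over to every group containing a five-membered aromatic ring with one sulfur. Nothing available explains why the fused ring has this effect.

On these data alone, it remains open whether a smaller addition to the thiophene, such as a single methyl or a chlorine, would also raise the number. The compounds shown also leave open how furan-2-yl or pyridin-3-yl would behave in this place.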